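A few compounds are considered here, and "the series" means these few. Any claim that something is new, unique, unknown or untested is made for them only; others in the source may bear on it.

Three compounds built on one shared core have been run in a functional assay on the whole organism for inhibition, with Rattus norvegicus as the target, at a dose of 25 mg/kg by the intraperitoneal route; on this read-out lower numbers stand for less inhibition and higher numbers for more inhibition at the one dose given (going by the name of the read-out). Compound 1 `CN(C)c1ncnc2c1ncn2C` gives 30% in this assay. Compound 2 `CCCCCn1cnc2c(N(C)C)ncnc21` gives 0% in this assay. Compound 3 `CN(C)c1ncnc2c1ncn2C1CCCC1` gives 27% in this assay. On these numbers compound 3 stands second highest of the three, with compound 1 as its nearest neighbour within the scatter and compound 2 as the furthest, well below it. The known steps run as follows: a number 30 percentage points lower from compound 1 to compound 2 (beyond the scatter); a number 27 percentage points higher from compound 2 to compound 3 (beyond the scatter); and a number 3 percentage points lower from compound 1 to compound 3 (within the scatter).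

The next compound is compound 4 `CN(C)c1ncnc2c1ncn2C1CCCCC1`, which differs from compound 3 in one place: cyclohexyl in place of cyclopentyl on an aromatic nitrogen. Within the data shown here, no measured step exchanges one carbon ring for another of a different size, so the bearing steps are indirect. The two steps that introduce the cyclopentyl show that a ring at this nitrogen sits level with methyl and well above pentyl, while the butyl extension of a chain cost most of the inhibition. Widening the ring by a single carbon is a smaller change than either, so no step beyond the scatter is expected, perhaps a slight dip. Compound 4 is therefore estimated at 24% in this assay, within a range from 5% to 42%, which means an expected step of a number 3 percentage points lower from compound 3 to compound 4 (within the scatter).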

Compound 4, a percentage reported as inhibition, in the whole organism at one dose (the size of the read-out at that dose, not a potency): 70%
Beside the measured number, compound 4's estimate is 46 percentage points below it, outside the stated range (above it).
By their numbers in this assay, from the lowest: compound 2; then compounds 3 and 1 (each within the scatter of the next); then compound 4.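

At this aromatic nitrogen, the two carbon rings are not interchangeable: in this assay cyclopentyl in place of methyl gave a number 3 percentage points lower from compound 1 to compound 3 (within the scatter) while cyclohexyl in place of cyclopentyl gave a number 43 percentage points higher from compound 3 to compound 4 (beyond the scatter) and so separated the six-membered ring from the five-membered one. Cyclohexyl also stands clear of the other two groups at this nitrogen, with a number 70 percentage points higher from compound 2 to compound 4 (beyond the scatter) on replacing pentyl and a number 40 percentage points higher from compound 1 to compound 4 (beyond the scatter) on replacing methyl, which makes compound 4 the highest of the four compounds, since its steps to all the others lie beyond the scatter. Nothing available here accounts for this jump.

On these data alone, whether the rise goes on with cycloheptyl or depends on a saturated ring at all remains open, and phenyl, benzyl or hexyl at the same nitrogen would bear on that question. Each compound also has a reading at only one dose in this assay and so the numbers leave open how the compounds would compare at other doses or by another route.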